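The compounds below may be only part of what the source reports. "The series", "measured", "known", "first", "only" and "open" are said of these compounds alone.

Working notes on the series, read in a functional assay on NCI-H520 cells (Homo sapiens); on this read-out higher numbers stand for weaker inhibition of growth and lower numbers for stronger inhibition of growth. Compound 1 `N#Cc1ccc(/C=C/S(=O)(=O)Cc2ccc(Nc3ncnc4ccccc34)cc2)cc1` gives > 100000 nM, which is a limit of the assay and not a number. Going by the values given here, compound 2 `O=S(=O)(/C=C/c1ccc(C(F)(F)F)cc1F)Cc1ccc(Nc2ncnc3ccccc23)cc1` gives 100000 nM, the only actual number so far. Among the compounds with values here, the single measured step, a number no higher from compound 1 to compound 2 (the limit leaves the size open), has no readable size, and the remaining evidence is the limit of > 100000 nM in this assay, at which 1 of the 2 values shown sits.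

Compound 3 `O=S(=O)(/C=C/c1ccc(O)cc1)Cc1ccc(Nc2ncnc3ccccc23)cc1` has 4-hydroxyphenyl in place of 2-fluoro-4-(trifluoromethyl)phenyl on a double-bonded chain carbon bound to a double-bonded chain carbon. Within the data shown here, no measured step gives a size for this change, so a step beyond the scatter in this assay is not expected, and no direction is firmly supported. The expected change, a 1.7-fold lower number from compound 2 to compound 3 (0.22 log units; within the scatter), is an estimate that leans only slightly towards stronger growth inhibition. For compound 3 the estimated value is 60000 nM, with an expected range of 10000 nM to 100000 nM.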

Compound 3, concentration for 50% growth inhibition: 100000 nM
For compound 3 the middle estimate is 1.7-fold (0.22 log units) below the measured one, within the range that was stated.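

On this assay this position now gives its first step of readable size: no change at the digits printed from compound 2 to compound 3 (within the scatter) for the change to 4-hydroxyphenyl, although that change removes all the fluorine of 2-fluoro-4-(trifluoromethyl)phenyl and brings in a hydrogen-bond donor and a hydrogen-bond acceptor. Like the earlier step that rests on the same limit, a number no higher from compound 1 to compound 3 (the limit leaves the size open) cannot be read for size. A flat step here therefore says little about how far this position can move the number, and the evidence that frames it is this: the limit of > 100000 nM in this assay, at which 1 of the 3 values shown sits.

Going by these compounds, whether another group on this double-bonded chain carbon, such as an amine, a carboxylic acid or a longer chain, would give a lower number stays open. The compounds shown also leave open whether a change to the shared core would shift the number.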